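This account rests on a few compounds, and the source may have more. Where it says the series, first, only, none or still open, it means among the compounds named here.

Compounds measured in a functional assay on Caco-2 cells (Homo sapiens) for antiproliferative activity, read by MTT assay, with a stated time of 48 h; on this read-out higher numbers stand for weaker inhibition and lower numbers for stronger inhibition:
compound 1 `CCn1c(C(=O)NCCN(C)C)ccc1C(CC)(CC)c1ccc(OCCC(O)(CC)CC)c(C)c1`, giving 1140 nM
compound 2 `CCOc1ccc(NC(=O)c2ccc(C(CC)(CC)c3ccc(OCCC(O)(CC)CC)c(C)c3)n2CC)cc1`, giving > 50000 nM, which is a limit of this assay rather than a number
compound 3 `CCOC(=O)CN(C)C(=O)c1ccc(C(CC)(CC)c2ccc(OCCC(O)(CC)CC)c(C)c2)n1CC`, giving 30300 nM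

Compound 1 gives the lowest number among the values shown; its nearest measured neighbour is compound 3, at a 27-fold higher number from compound 1 to compound 3 (1.42 log units; beyond the scatter), while compound 2 sits at the limit (the limit of > 50000 nM in this assay, at which 1 of the 3 values shown sits). The step from compound 2 to compound 3 is an at least 1.6-fold lower number from compound 2 to compound 3 (0.21 log units; that floor lies within the scatter).

Compound 4 is `CCn1c(C(=O)NC(CC(=O)O)C(=O)OC)ccc1C(CC)(CC)c1ccc(OCCC(O)(CC)CC)c(C)c1`. It differs from compound 1 in one place: a group of 9 heavy atoms (5 carbon, 4 oxygen; no ring) in place of a group of 5 heavy atoms (4 carbon, 1 nitrogen; no ring), on an amide-type nitrogen.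

Within the data shown here, two measured steps bear on this change, since both also replace the 2-(dimethylamino)ethyl group of compound 1 on the amide-type nitrogen or the neighbouring carbonyl carbon: an at least 43-fold higher number from compound 1 to compound 2 (1.64 log units; beyond the scatter) and a 27-fold higher number from compound 1 to compound 3 (1.42 log units; beyond the scatter). Both are large, in the same direction. The group entering in compound 4 is again unlike the group that leaves, so a large step upward in this assay is expected for the step from compound 1 to compound 4 as well, estimated at a 22-fold higher number from compound 1 to compound 4 (1.34 log units; beyond the scatter). Compound 4 is therefore expected to give about 25000 nM, with a likely range from 7000 nM to 60000 nM, and a real chance that only a limit is reported.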

Compound 4, half-maximal inhibitory concentration: 25200 nM
For compound 4 the middle estimate is 1.0-fold (0.00 log units) below the measured one, and the stated range covers the measured number.
By their numbers in this assay, from the lowest: compound 1; then compounds 4 and 3 (each within the scatter of the next). At a limit, above all of these: compound 2.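

In this assay, replacing the 2-(dimethylamino)ethyl group on the amide-type nitrogen with a group containing no nitrogen, which has 1 hydrogen-bond donor and 3 hydrogen-bond acceptors, gives a 22-fold higher number from compound 1 to compound 4 (1.34 log units; beyond the scatter), so a third, different replacement also falls well short of compound 1, and no compound shown without the 2-(dimethylamino)ethyl group comes near it. Exchanging one of these replacements for the other on the carbonyl carbon gives a 1.2-fold lower number from compound 3 to compound 4 (0.08 log units; within the scatter), so this assay does not separate the two, and the large gap from compound 1 appears with both. Compound 2 gives only a limit: the limit of > 50000 nM in this assay, at which 1 of the 4 values shown sits. Read against that limit, the comparison gives an at least 1.9-fold lower number from compound 2 to compound 4 (0.29 log units; that floor lies within the scatter), so it establishes no difference beyond the scatter.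

What the compounds shown leave open is which part of the 2-(dimethylamino)ethyl group goes with the lower number in compound 1, since each replacement shown removes the whole group at once. A 2-aminoethyl group, a 2-hydroxyethyl group or a 3-(dimethylamino)propyl chain on the same nitrogen would separate the role of the dimethylamino nitrogen from that of the chain length.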